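The source may hold more compounds than are shown below. What is called first, only, known or untested is meant among the compounds shown, and "the series" means these compounds.

- compound 1 `O=C(CCCCC(S)CCS)Nc1ccc(Cl)cc1`: 1.04%
- compound 2 `O=C(CCCCC(S)CCS)Nc1ccc(OC(F)(F)F)cc1`: "not active" (no number reported)

In a functional assay on HO8910 cells (Homo sapiens) for inhibition, read by MTT assay, with a stated time of 24 h, tested at 0.1 ug/mL (on this read-out lower numbers stand for less inhibition of growth and higher numbers for more inhibition of growth at the one concentration tested), compound 2 has no single number and is reported only as "not active" (no number reported). Compound 3 `COc1ccc(NC(=O)CCCCC(S)CCS)cc1`, not yet measured, has methyl in place of trifluoromethyl on an oxygen on an aromatic ring, a change from trifluoromethoxy to methoxy: methyl in place of trifluoromethyl on an oxygen on an aromatic ring. Among the compounds with values here, no measured pair shows this change. Within the data shown here, with compound 1 at 1.04% as the only number available, no step beyond the scatter is expected in this assay. For compound 3 the estimated value is 3%, with an expected range of 0% to 12%.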

Compound 3, percent growth inhibition at one concentration: "not active" (no number reported)
Compound 3 has no reported number here; no gap can be computed for the estimate.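

In this assay, compound 2 and compound 3 both lack a reported number, so no step can be read between them. Nothing shown offers an explanation for this result. The compounds shown leave open whether trifluoromethoxy and methoxy differ in their effect on growth.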